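The source may report more compounds than this note shows. Statements on the series, on what has been measured and on what is new or still open speak of the compounds shown alone.

Working notes on the series

The compounds share the core seen in compound 1 `Cc1cccc(C2CC(c3ccccc3)=NN2c2ccc(S(N)(=O)=O)cc2)c1`, which in an ADME assay on MT4 cells (Homo sapiens) for cytotoxicity, read by MTT assay, with a stated time of 96 h (on this read-out lower numbers stand for higher toxicity in this test and higher numbers for lower toxicity in this test), gives 37000 nM. Compound 3 `Cc1ccc(C2CC(c3ccccc3)=NN2c2ccc(S(N)(=O)=O)cc2)cc1` gives 40000 nM in this assay and stands highest of the two numbers in hand, with compound 1 nearest to it; the step of a 1.1-fold higher number from compound 1 to compound 3 (0.03 log units; within the scatter) lies within the scatter, so the two cannot be ordered. Compound 2 `Cc1ccccc1C1CC(c2ccc(OCc3ccccc3)cc2)=NN1c1ccc(S(N)(=O)=O)cc1`, which also bears a 2-methylphenyl group on the saturated ring carbon but differs elsewhere in the molecule, is reported in this assay only as a limit, >= 100000 nM. One of the three results in hand is such a limit (the limit of >= 100000 nM in this assay, at which 1 of the 3 values shown sits).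

Compound 4 `Cc1ccccc1C1CC(c2ccccc2)=NN1c1ccc(S(N)(=O)=O)cc1` has not yet been measured. It differs from compound 3 in one place: 2-methylphenyl in place of 4-methylphenyl on a saturated ring carbon. Among the measured compounds shown here, the only measured step that bears on an exchange of one methylphenyl for another is the one from compound 1 to compound 3, and that step stayed within the scatter. On that basis no step beyond the scatter is expected in this assay in either direction, though a limit cannot be excluded given that compound 2 carrying the same 2-methylphenyl group sits at one. Compound 4 is therefore expected to give about 45000 nM, with a range from 20000 nM to 100000 nM, which would mean an estimated step of a 1.1-fold higher number from compound 3 to compound 4 (0.05 log units; within the scatter).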

Compound 4, half-maximal cytotoxic concentration: 43000 nM
The estimate for compound 4 lay 1.0-fold (0.02 log units) above the measured number; the measured number falls inside the stated range.
By their numbers in this assay, from the lowest: compounds 1, 3 and 4 (each within the scatter of the next). At a limit, above all of these: compound 2.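

In this assay, all three methylphenyl placements on the saturated ring carbon can now be compared, and the 2-methylphenyl group, which lies next to the ring nitrogen, gives a 1.1-fold higher number from compound 3 to compound 4 (0.03 log units; within the scatter) and a 1.2-fold higher number from compound 1 to compound 4 (0.07 log units; within the scatter), so these three compounds cannot be ordered and this exchange shows no effect of placement at this position. Among the compounds shown here, the one step that leaves the scatter lies elsewhere in the molecule, with hydrogen in place of benzyloxy on an aromatic carbon giving an at least 2.3-fold lower number from compound 2 to compound 4 (0.36 log units; beyond the scatter), which is the first sign that a change away from this position can move the number when the 2-methylphenyl group is held fixed. That step has only a minimum size, since compound 2 stands as a limit of the assay and not as a number: the limit of >= 100000 nM in this assay, at which 1 of the 4 values shown sits.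

On these data alone, whether a group on that phenyl ring other than methyl, such as an amine, a carboxylic acid or a longer alkyl chain, would move the number beyond the scatter stays open. Also open, as far as these compounds go, is whether benzyloxy would give a step of similar size alongside the 3-methylphenyl or 4-methylphenyl group.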